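Enlarging the Nitrogen Substituent of a Bridged Amine

The source may report more compounds than this note shows. Statements on the series, on what has been measured and on what is new or still open speak of the compounds shown alone.

Compound 1 `c1ccc2c(c1)C1CCNCC2C1` gives 4.9 mg/kg.
Compound 2 `CN1CCC2CC(C1)c1ccccc12` gives 4.2 mg/kg.
Compound 3 `CCCN1CCC2CC(C1)c1ccccc12` gives 16.2 mg/kg.

These three compounds share one core and differ only in the group on the ring amine nitrogen, all assessed in a functional assay on the whole organism with Mus musculus as the target, in the hot plate test; on this read-out higher numbers stand for an effect only at larger amounts of compound and lower numbers for an effect already at smaller amounts. Compound 1 stands second highest of the three numbers; compound 2 lies nearest to it and compound 3 furthest. The step of a 1.2-fold lower number from compound 1 to compound 2 (0.07 log units; within the scatter) stays within the scatter, whereas a 3.3-fold higher number from compound 1 to compound 3 (0.52 log units; beyond the scatter) goes beyond it, as does a 3.9-fold higher number from compound 2 to compound 3 (0.59 log units; beyond the scatter).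

Compound 4 `CC(C)=CCN1CCC2CC(C1)c1ccccc12` has not yet been measured. It differs from compound 1 by 3-methylbut-2-en-1-yl in place of hydrogen on an amine nitrogen in a ring. The measured step that bears most directly on this change is a 3.3-fold higher number from compound 1 to compound 3 (0.52 log units; beyond the scatter), where a propyl group on the same nitrogen raised the number modestly; the step of a 1.2-fold lower number from compound 1 to compound 2 (0.07 log units; within the scatter), with the smallest group, did not move beyond the scatter. The group entering in compound 4 is larger than propyl, so a modest rise in this assay, in the same direction as that seen for compound 3, is expected rather than a fall.

Compound 4 is therefore estimated at 20 mg/kg, with an expected range from 8 mg/kg to 50 mg/kg. This corresponds to an expected step of a 4.1-fold higher number from compound 1 to compound 4 (0.61 log units; beyond the scatter).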

Compound 4, dose for half-maximal effect: "not active" (no number reported)
For compound 4 the study gives words and no number, and the estimate cannot be compared.
By their numbers in this assay, from the lowest: compounds 2 and 1 (each within the scatter of the next); then compound 3.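

In this assay compound 4 is reported only as "not active", without a number, so no step can be read between it and compound 1, compound 2 or compound 3. The compounds shown leave open how other groups on this nitrogen, larger than propyl, would read out. Nothing given here accounts for this result.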